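This account rests on a few compounds, and the source may have more. Where it says the series, first, only, none or still open, it means among the compounds named here.

Within the data shown here, compound 2 (`CCC(=O)N1CCc2nc(C#Cc3ccccc3)sc2C1`) gives 38 nM in an assay on HEK293 cells for negative allosteric modulation of metabotropic glutamate receptor 5 (Homo sapiens), read by FLIPR, with a stated time of 1 h (on this read-out lower numbers stand for stronger inhibition and higher numbers for weaker inhibition), and stands lowest of the two numbers measured so far; its only neighbour, compound 1 (`CC(C)CN1CCc2nc(C#Cc3ccccc3)sc2C1`), gives 650 nM in this assay. Among the measured compounds shown here, the single measured step, a 17-fold lower number from compound 1 to compound 2 (1.23 log units; beyond the scatter), came from putting propanoyl in place of isobutyl on the amine nitrogen in the ring, and that carbonyl is kept in the compound considered next. Compound 3 (`O=C(C1CC1)N1CCc2nc(C#Cc3ccccc3)sc2C1`) differs from compound 2 by cyclopropyl in place of ethyl on a carbonyl carbon. For the measured compounds named here, no measured step addresses a change of this kind; the large step from compound 1 to compound 2 concerns the group on the ring nitrogen, not the group on the carbonyl carbon, so it offers no direct guide. The change is expected to move this assay by no more than the scatter, as a 1.3-fold lower number from compound 2 to compound 3 (0.10 log units; within the scatter). Compound 3 is therefore estimated at 30 nM, within 10 nM to 90 nM.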

Compound 3, half-maximal inhibitory concentration: 290 nM
For compound 3 the middle estimate is 9.7-fold (0.99 log units) below the measured one; measured number above the stated range.
By their numbers in this assay, from the lowest: compound 2; then compound 3; then compound 1.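

At this position the group on the carbonyl carbon is not a neutral detail in this assay: cyclopropyl in place of ethyl gives a 7.6-fold higher number from compound 2 to compound 3 (0.88 log units; beyond the scatter), so a small change here shifts the number beyond the scatter. The carbonyl alone does not secure the full gain over isobutyl on the ring nitrogen, as cyclopropylcarbonyl in place of isobutyl gives only a 2.2-fold lower number from compound 1 to compound 3 (0.35 log units; beyond the scatter), against a 17-fold lower number from compound 1 to compound 2 (1.23 log units; beyond the scatter) for propanoyl. No available evidence bears on what lies behind this difference between the two carbonyl groups.

From the compounds shown here alone, whether the loss goes with the three-membered ring or with the added carbon stays open. So does whether isopropyl or a longer chain on the carbonyl carbon would behave like ethyl or like cyclopropyl.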